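The source may hold more compounds than are shown below. What is called first, only, known or untested is meant among the compounds shown, and "the series" means these compounds.

Compound 1 `CC(C)c1noc(N2CCN(C(=O)[C@@H]3CCCN(S(=O)(=O)c4ccc(S(=O)(=O)C(C)C)cc4)C3)CC2)n1` — 30 nM
Compound 2 `CCOC(=O)[C@@H]1CCCN(S(=O)(=O)c2ccc(S(=O)(=O)N(CC)C(C)C)cc2)C1` — 1200 nM
Compound 3 `CCOC(=O)N1CCC[C@@H](S(=O)(=O)c2ccc(S(=O)(=O)N(CC)CC)cc2)C1` — > 10000 nM

In a functional assay on MIA PaCa-2 cells (Homo sapiens) for inhibition, read by MTT assay, with a stated time of 3 days (a higher number here means a weaker inhibitor, a lower number a stronger inhibitor), compound 1 holds the lowest of the two numbers shown, and the gap to compound 2 lies beyond the scatter. Compound 3 sits at the limit of > 10000 nM in this assay, at which 1 of the 3 values shown sits: its reading is a limit, not a number. Compound 4 `CC(C)c1noc(N2CCN(C(=O)[C@@H]3CCCN(S(=O)(=O)c4ccc(S(=O)(=O)NC5CCC5)cc4)C3)CC2)n1` keeps the core of compound 1 and differs in one place: cyclobutylamino in place of isopropyl on a sulfonyl sulfur. Among the compounds with values here, no pair of measured compounds separates this change on its own, so compound 2 and compound 3 give no direct guide to its size. In this assay compound 4 is expected to stay close to compound 1, with a step of a 1.7-fold higher number from compound 1 to compound 4 (0.22 log units; within the scatter) that is expected to lie within the scatter or slightly toward a higher number. Compound 4 is therefore estimated at 50 nM, between 15 nM and 200 nM.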

Compound 4, half-maximal inhibitory concentration: 200 nM
Beside the measured number, compound 4's estimate is 4.0-fold (0.60 log units) below it; the range from low to high includes it.
By their numbers in this assay, from the lowest: compound 1; then compound 4; then compound 2. At a limit, above all of these: compound 3.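

In this assay, cyclobutylamino in place of isopropyl on a sulfonyl sulfur gives a 6.7-fold higher number from compound 1 to compound 4 (0.82 log units; beyond the scatter). Within the data shown here, this is the first comparison in the set that changes one place only, and it shows that the potency of this series responds to the group at this position. Nothing measured here accounts for the size of this step. From the compounds shown here alone, whether the step belongs to the ring or to the nitrogen with its hydrogen stays open: a cyclobutyl group placed directly on the sulfonyl sulfur, or a dimethylamino group, would separate the two.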